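The compounds below may be only part of what the source reports. "The series", "measured", "known", "first", "only" and "open" are said of these compounds alone.

In a functional assay on SMMC-7721 cells (Homo sapiens) for inhibition, read by MTT assay, with a stated time of 48 h (a lower number here means a stronger inhibitor, a higher number a weaker inhibitor), compound 1 (`COc1ccc(-c2cc(NC(=O)Nc3ccncc3)cc(OC)c2OC)cn1`) reads "not determined" (no result reported), and compound 2 (`O=C(Nc1ccncc1)Nc1cc(-c2cccnc2)cc(C(F)(F)F)c1`) reads "not determined" (no result reported), so neither supplies a number. Compound 3 (`O=C(Nc1cc(-c2cccnc2)cc(C(F)(F)F)c1)Nc1nccs1`) gives 68200 nM. Among the compounds with values here, this is the only number available, so compound 3 cannot yet be ranked against any other compound. Compound 4 (`O=C(Nc1cc(-c2cncnc2)cc(C(F)(F)F)c1)Nc1nccs1`) awaits measurement and differs from compound 3 by one exchange: pyrimidin-5-yl in place of pyridin-3-yl on an aromatic carbon. In words, pyrimidin-5-yl stands in place of pyridin-3-yl on an aromatic carbon. Within the data shown here, no measured step exists to guide the expectation, so no step beyond the usual scatter is expected in this assay, and no direction is favoured. The estimated step is a 1.1-fold higher number from compound 3 to compound 4 (0.04 log units; within the scatter). Compound 4 is expected at 75000 nM, with an estimated range of 25000 nM to 200000 nM.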

Compound 4, half-maximal inhibitory concentration: 29700 nM
Estimate against measurement, compound 4: 2.5-fold (0.40 log units) above; the range from low to high includes it.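

Within the data shown here, at this place, on an aromatic carbon meta to a trifluoromethyl group, pyrimidin-5-yl in place of pyridin-3-yl gives the first readable step in this assay, namely a 2.3-fold lower number from compound 3 to compound 4 (0.36 log units; beyond the scatter), so the number at this position responds to this ring exchange. This rests on a single pair, and nothing at hand bears on why the number moves. The compounds shown leave open how a plain phenyl ring or an amine at this place would read, and whether the same exchange gives a similar step on other cores.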